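This account rests on a few compounds, and the source may have more. Where it says the series, first, only, none or still open, it means among the compounds named here.

Measured so far in an assay on isolated protein for inhibition of phosphatidylinositol 4,5-bisphosphate 3-kinase catalytic subunit beta isoform (Homo sapiens), read by 33P incorporation, with a stated time of 60 min; a higher number here means a weaker inhibitor, a lower number a stronger inhibitor:

compound 1 `COc1ccc([N+](=O)[O-])cc1S(=O)(=O)N(C)/N=C/c1cnn2ccc(C#N)cc12`: 63 nM
compound 2 `Cc1ccc(N)cc1S(=O)(=O)N(C)/N=C/c1cnn2ccc(C#N)cc12`: > 1000 nM
compound 3 `Cc1ccc([N+](=O)[O-])cc1S(=O)(=O)N(Cc1ccccc1)/N=C/c1cnn2ccc(C#N)cc12`: > 1000 nM

Compound 1 is the only one of the three with a number in this assay, giving 63 nM. For compound 2 the result is a limit of the assay, > 1000 nM. For compound 3 the result is likewise a limit, > 1000 nM. Two of the three results therefore sit at the limit of > 1000 nM in this assay, at which 2 of the 3 values shown sit, and compounds 2 and 3 each differ from compound 1 in more than one place, so no single step can be read from them.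

Compound 4 `CN(/N=C/c1cnn2ccc(C#N)cc12)S(=O)(=O)c1cc([N+](=O)[O-])ccc1F` differs from compound 1 by fluoro in place of methoxy on an aromatic carbon. The step from compound 1 to compound 4 is expected to be small, within the scatter or a slight loss, a 1.6-fold higher number from compound 1 to compound 4 (0.20 log units; within the scatter). Compound 4 is estimated at 100 nM, in the range 30 nM to 400 nM.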

Compound 4, half-maximal inhibitory concentration: 44 nM
For compound 4 the middle estimate is 2.3-fold (0.36 log units) above the measured one; the measured number falls inside the stated range.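

In this assay, fluoro in place of methoxy, on the aromatic carbon ortho to a large group and para to a nitro group, gives a 1.4-fold lower number from compound 1 to compound 4 (0.16 log units; within the scatter). Within the data shown here, this is the first single-place comparison, and it shows that this position accepts the smaller fluoro, without the hydrogen-bond acceptor counted on methoxy, with no change beyond the scatter. Nothing at hand gives a cause for this step.

From the compounds shown here alone, what remains open is how this position responds to a bare hydrogen, an amine, a carboxylic acid or a longer alkoxy chain.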